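From 3-chlorophenyl to 4-methylphenyl: compound 3 and compound 4

A few compounds are considered here, and "the series" means these few. Any claim that something is new, unique, unknown or untested is made for them only; others in the source may bear on it.

Measured in a functional assay on A549 cells (Homo sapiens) for inhibition, read by CCK-8 assay, with a stated time of 72 h, tested at 10 uM; on this read-out higher numbers stand for more inhibition of growth at the one concentration tested and lower numbers for less inhibition of growth:
- compound 1 `CN(C)C(=O)c1cc2cnc(Nc3ccc(NC(=O)C4(C(=O)Nc5ccc(F)cc5)CC4)cc3)nc2n1C1CCCC1`: 102%
- compound 2 `Cc1cccc(NC(=O)C2(C(=O)Nc3ccc(Nc4ncc5cc(C(=O)N(C)C)n(C6CCCC6)c5n4)cc3)CC2)c1`: 86.1%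
- compound 3 `CN(C)C(=O)c1cc2cnc(Nc3ccc(NC(=O)C4(C(=O)Nc5cccc(Cl)c5)CC4)cc3)nc2n1C1CCCC1`: 90.7%

Compound 3 sits close to compound 2 on these numbers, with a number 4.6 percentage points higher from compound 2 to compound 3 (within the scatter), while compound 1 stands clear of both, with a number 11.3 percentage points lower from compound 1 to compound 3 (beyond the scatter) and a number 15.9 percentage points lower from compound 1 to compound 2 (beyond the scatter). Compound 4 `Cc1ccc(NC(=O)C2(C(=O)Nc3ccc(Nc4ncc5cc(C(=O)N(C)C)n(C6CCCC6)c5n4)cc3)CC2)cc1` differs from compound 3 by 4-methylphenyl in place of 3-chlorophenyl on an amide-type nitrogen. In short, 4-methylphenyl takes the place of 3-chlorophenyl on an amide-type nitrogen.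

The step from compound 2 to compound 3 is the nearest guide, since it exchanges methyl and chloro, and it stays within the scatter. Among the compounds with values here, the two modest steps away from compound 1 are the only sign that the aryl group matters, but compound 1 carries 4-fluorophenyl, and no measured compound carries 4-methylphenyl. No clear direction is therefore expected, and the expected change is a number 1.3 percentage points higher from compound 3 to compound 4 (within the scatter), with no step beyond the scatter.

Compound 4 is expected at 92%, within an estimated range of 80% to 104%.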

Compound 4, percent growth inhibition at one concentration: 90.6%
Beside the measured number, compound 4's estimate is 1.4 percentage points above it, within the range that was stated.
By their numbers in this assay, from the lowest: compounds 2, 4 and 3 (each within the scatter of the next); then compound 1.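

In this assay the exchange of 3-chlorophenyl for 4-methylphenyl on the amide-type nitrogen gives a number 0.1 percentage points lower from compound 3 to compound 4 (within the scatter) and so adds a second case in which methyl and chloro cannot be told apart, this time on different aryl groups. The change from 3-methylphenyl to 4-methylphenyl gives a number 4.5 percentage points higher from compound 2 to compound 4 (within the scatter) and shows that, for the methyl group, the two named arrangements cannot be told apart here either. Only 4-fluorophenyl stands apart, since the exchange of fluoro for methyl gives a number 11.4 percentage points lower from compound 1 to compound 4 (beyond the scatter) and no data at hand account for this gap.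

Going by these compounds, whether a methoxy group, a carboxylic acid or an amine on this phenyl ring would hold the read-out remains open. So does whether compound 2, compound 3 and compound 4 would separate at other concentrations.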